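Two chlorines in place of one on the outer ring

This account rests on a few compounds, and the source may have more. Where it says the series, first, only, none or still open, it means among the compounds named here.

Compound 3 `N[C@@H](COP(=O)(O)OCCCOC(=O)CCc1ccccc1OCc1cccc(Oc2ccccc2Cl)c1)C(=O)O` gives 0.069 in an assay on cells for activation of probable G-protein coupled receptor 34 (Mus musculus), with a stated time of 1 h (on this read-out higher numbers stand for larger maximal responses and lower numbers for smaller maximal responses), the lowest of the three numbers seen. Compound 1 `Cc1ccccc1Oc1cccc(COc2ccccc2CCC(=O)OCCCOP(=O)(O)OC[C@H](N)C(=O)O)c1` gives 0.28 and compound 2 `Cc1cccc(Oc2cccc(COc3ccccc3CCC(=O)OCCCOP(=O)(O)OC[C@H](N)C(=O)O)c2)c1` gives 0.29, and the step between them, a number 0.010 higher from compound 1 to compound 2 (within the scatter), lies within the scatter. The steps to compound 3 were a number 0.21 lower from compound 1 to compound 3 (beyond the scatter) and a number 0.22 lower from compound 2 to compound 3 (beyond the scatter). Compound 4 `N[C@@H](COP(=O)(O)OCCCOC(=O)CCc1ccccc1OCc1cccc(Oc2ccc(Cl)c(Cl)c2)c1)C(=O)O` differs from compound 3 by 3,4-dichlorophenyl in place of 2-chlorophenyl on an oxygen on an aromatic ring. Going by the values given here, no measured step adds a second chlorine; the one change to a chlorine lowered the maximal response modestly, while exchanging 2-methylphenyl for 3-methylphenyl changed little. Compound 4 is therefore expected to stay near compound 3. Compound 4 is estimated at 0.12, ranging from 0.04 to 0.3. The expected step is a number 0.051 higher from compound 3 to compound 4 (within the scatter), within the scatter.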

Compound 4, intrinsic activity: the largest response reached, as a fraction of the reference agonist's: 0.71
Compound 4: the middle estimate sits 0.59 below what was measured; the whole stated range lies below it.
By their numbers in this assay, from the lowest: compound 3; then compounds 1 and 2 (each within the scatter of the next); then compound 4.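

In this assay, going by these compounds alone, this position on the oxygen tolerates far more than the earlier compounds showed: 3,4-dichlorophenyl in place of 2-chlorophenyl raises the maximal response (a number 0.64 higher from compound 3 to compound 4 (beyond the scatter)), so chlorine on the outer ring does not in itself lower it. The same group also stands clear of both methylphenyl groups (a number 0.42 higher from compound 2 to compound 4 (beyond the scatter)) and (a number 0.43 higher from compound 1 to compound 4 (beyond the scatter)), making compound 4 the highest of the four. Nothing measured here explains this rise.

The compounds shown leave open whether the rise needs both chlorines. They also leave open whether a bromine or a methoxy group in place of these chlorines would keep it.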